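The source may report more compounds than this note shows. Statements on the series, on what has been measured and on what is new or still open speak of the compounds shown alone.

Measured so far in a functional assay on cells (Platelet, Homo sapiens) for inhibition; on this read-out lower numbers stand for stronger inhibition and higher numbers for weaker inhibition:
Compound 1 `CCOC(=O)c1ccc(-c2nn(CC)c3ccccc23)cc1`: > 10000 nM, a limit of the assay.
Compound 2 `CCCCn1nc(-c2ccc(C(=O)OCC)cc2)c2ccccc21`: > 10000 nM, a limit of the assay.
Compound 3 `COC(=O)c1ccc(-c2nn(Cc3ccccc3)c3ccccc23)cc1`: > 10000 nM, a limit of the assay.

Compound 2 differs from compound 1 by ethyl in place of hydrogen on a saturated chain carbon, two bonds along the chain from an aromatic nitrogen. The step that the two limits leave unreadable from compound 1 to compound 2 cannot be read because both values sit at the limit of > 10000 nM in this assay, at which 3 of the 3 values shown sit. The difference between the core of compound 1 and the core of compound 3 is not broken down here.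

Compound 4 `CCCOC(=O)c1ccc(-c2nn(Cc3ccccc3)c3ccccc23)cc1` is not yet measured. It differs from compound 3 by ethyl in place of hydrogen on a saturated chain carbon bound to an oxygen next to a carbonyl group, the same kind of change as that from compound 1 to compound 2, though the place differs: here a saturated chain carbon bound to an oxygen next to a carbonyl group, there a saturated chain carbon two bonds along the chain from an aromatic nitrogen. For the measured compounds named here, since every value so far rests at the limit of > 10000 nM in this assay, at which 3 of the 3 values shown sit, compound 4 is expected to stay weak in this assay, around 20000 nM, between 5000 nM and 80000 nM, an expected step that the limit leaves unreadable from compound 3 to compound 4 that most likely again yields only a limit.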

Compound 4, half-maximal inhibitory concentration: > 10000 nM
Compound 4: only a limit was reported (the forecaster's own chance of this, stated with the estimate: 85%); the middle value does not contradict the limit.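

The step between compound 3 and compound 4 cannot be read, as both values are limits of the assay: the limit of > 10000 nM in this assay, at which 4 of the 4 values shown sit.

The compounds shown leave open whether any change among them alters inhibition in this assay at all.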